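The source may report more compounds than this note shows. Statements on the series, on what has been measured and on what is new or still open speak of the compounds shown alone.

Compound 2 `O=C(CSC(=S)N[C@H]1CCOC1=O)Nc1ccccc1` gives in a functional assay on SMMC-7721 cells (Homo sapiens) for cytotoxicity, read by MTT assay, with a stated time of 72 h (a higher number here means a weaker inhibitor, a lower number a stronger inhibitor), only a limit, > 128000 nM. Compound 1 `O=C(CSC(=S)N[C@H]1CCOC1=O)Nc1ccc(Br)cc1` gives 28300 nM. The change bromo in place of hydrogen on an aromatic carbon produced an at least 4.5-fold lower number from compound 2 to compound 1 (0.65 log units; beyond the scatter). Compound 3 `O=C(CSC(=S)N[C@H]1CCOC1=O)Nc1ccc(C(=O)/C=C/c2ccccc2)cc1` also gives only a limit, > 128000 nM. Its core differs from that of compound 2 by (2-phenylethenyl)carbonyl in place of hydrogen on an aromatic carbon, and the two limits leave a step that the two limits leave unreadable from compound 2 to compound 3 unreadable, because of the limit of > 128000 nM in this assay, at which 2 of the 3 values shown sit. Against compound 1, there is an at least 4.5-fold higher number from compound 1 to compound 3 (0.65 log units; beyond the scatter). Compound 4 `O=C(CSC(=S)N[C@H]1CCOC1=O)Nc1ccc(C(=O)/C=C/c2ccc(Br)cc2)cc1` carries bromo in place of hydrogen on an aromatic carbon, the same kind of change as in compound 1, though cut one bond further out it reads 2-phenylethenyl to 2-(4-bromophenyl)ethenyl rather than phenyl to 4-bromophenyl. Because an at least 4.5-fold lower number from compound 2 to compound 1 (0.65 log units; beyond the scatter), compound 4 is expected to show an at least 1.8-fold lower number from compound 3 to compound 4 (0.26 log units; that floor lies within the scatter), though it starts from a limit. Compound 4 is estimated at 70000 nM, between 20000 nM and 200000 nM.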

Compound 4, half-maximal inhibitory concentration: 18000 nM
Beside the measured number, compound 4's estimate is 3.9-fold (0.59 log units) above it; the measured number lies below the stated range.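

In this assay, bromo in place of hydrogen on an aromatic carbon again gave a lower number on the second core, an at least 7.1-fold lower number from compound 3 to compound 4 (0.85 log units; beyond the scatter), and the direction of the change therefore held on both cores shown. This does not show that the change gives the same size of step on both cores, since each step starts from a limit and not from a number: the same change on two cores in this assay, an at least 4.5-fold lower number (0.65 log units; beyond the scatter) from compound 2 to compound 1 and an at least 7.1-fold lower number (0.85 log units; beyond the scatter) from compound 3 to compound 4; the limit leaves it open whether they differ. Two cores also establish no rule for the rest of the series, and neither unsubstituted parent compound has a measured number to start from: the limit of > 128000 nM in this assay, at which 2 of the 4 values shown sit.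

The compounds shown leave open whether chloro or a carboxylic acid in the place of the bromo would also lower the number. They also leave open whether the bromo change would hold on a core with a longer chain in place of the (2-phenylethenyl)carbonyl.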